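The source may report more compounds than this note shows. Statements on the series, on what has been measured and on what is new or still open speak of the compounds shown alone.

Working notes on the series. Compound 1 `CCCCCc1cc2c(=O)n(CCC)cnc2s1` has been run in an ADME assay on THP-1 cells (Homo sapiens) for cytotoxicity, read by MTT assay, with a stated time of 11 days; on this read-out lower numbers stand for stronger inhibition of growth and higher numbers for weaker inhibition of growth. In this assay compound 1 gives > 100 ug/mL, which is a limit of the assay and not a number. Compound 2 `CCCCCCCc1cc2c(=O)n(CC#N)cnc2s1` has been run as well; in this assay compound 2 gives > 100 ug/mL, again a limit and not a number. Every result in hand therefore sits at the limit of > 100 ug/mL in this assay, at which 2 of the 2 values shown sit, so compound 1 has no number of its own and cannot be placed above or below any other compound; the two results only show that neither compound reached half-maximal growth inhibition inside the tested range.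

Compound 3 `CCCCCc1cc2c(=O)n(CC3CC3)cnc2s1` has not yet been measured. Relative to compound 1 it carries cyclopropyl in place of ethyl on a saturated chain carbon bound to an aromatic nitrogen. For the measured compounds named here, no measured pair in the set differs in one place, so no measured step bears on this change. With both known results at the limit, the step that the limit leaves unreadable from compound 1 to compound 3 is expected to be none beyond the scatter. Compound 3 is expected to give 150 ug/mL in this assay, with a range from 60 ug/mL to 400 ug/mL, and most probably it is reported only as a limit once more.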

Compound 3, concentration for 50% growth inhibition: > 100 ug/mL
Compound 3: no number, only a limit; the forecaster's own chance of this, stated with the estimate: 80%; the middle value does not contradict the limit.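

No step can be read from compound 1 to compound 3, as both results are limits and not numbers, and the same holds for every other result in this assay: the limit of > 100 ug/mL in this assay, at which 3 of the 3 values shown sit. The compounds shown leave open whether cyclopropyl in place of ethyl alters growth inhibition at all, and at what concentration any of them would reach half-maximal growth inhibition.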